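Methyl in place of hydrogen at the assay limit

The source may report more compounds than this note shows. Statements on the series, on what has been measured and on what is new or still open speak of the compounds shown alone.

In an ADME assay on RAW264.7 cells (Mus musculus) for cytotoxicity, read by MTT assay, with a stated time of 24 h, in the absence of a further agent (on this read-out lower numbers stand for stronger inhibition and higher numbers for weaker inhibition), compound 2 `COc1cc(OC)c2c(c1)C(C(O)c1ccc(OCc3ccccc3)cc1)OC2=O` gives > 40000 nM, which is a limit of the assay and not a number. In this assay compound 1 `CCCCOc1ccc(C(O)C2OC(=O)c3c(OC)cc(OC)cc32)cc1` gives > 40000 nM, which is also a limit. Nothing more can be read from the pair than the limit of > 40000 nM in this assay, at which 2 of the 2 values shown sit.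

Compound 3 `COc1cc(OC)c2c(c1)C(C(O)c1ccc(OCc3ccc(C)cc3)cc1)OC2=O` differs from compound 2 by methyl in place of hydrogen on an aromatic carbon, para to a large group, so that benzyloxy becomes (4-methylbenzyl)oxy: methyl in place of hydrogen on an aromatic carbon.

Within the data shown here, only one measured change bears on this, and it lies in the same ether side chain. That change is a step that the two limits leave unreadable from compound 1 to compound 2, so it offers no size to carry over and no direction to follow. Any number for the new methyl group must therefore stay cautious in this assay.

The estimated step that the limit leaves unreadable from compound 2 to compound 3 is expected to lie within the scatter, with no direction that can be named. For compound 3 the estimate is 45000 nM, with an expected range from 25000 nM to 80000 nM, and a further limit is the likeliest report.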

Compound 3, half-maximal inhibitory concentration: > 40000 nM
Compound 3: no number, only a limit; the forecaster's own chance of this, stated with the estimate: 85%; the middle value does not contradict the limit.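

In this assay compound 3 gives > 40000 nM, which is a limit of the assay and not a number. Among these compounds, no step can therefore be read from compound 2 to compound 3 or from compound 1 to compound 3. The compounds shown leave open whether any change in the ether side chain shifts the read-out at all: the limit of > 40000 nM in this assay, at which 3 of the 3 values shown sit.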